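Swapping the Heterocycle on a Shared Core

The source may report more compounds than this note shows. Statements on the series, on what has been measured and on what is new or still open speak of the compounds shown alone.

All compounds here carry a heterocycle on a saturated chain carbon bound to a double-bonded chain carbon of one shared core. Compound 2 `Nc1ncn(C/C=C2\OC(=O)C(OCc3ccccc3)=C2OCc2ccccc2)c(=O)n1` gives 920 nM in a functional assay on MIA PaCa-2 cells (Homo sapiens) for inhibition, read by MTT assay, with a stated time of 72 h (a higher number here means a weaker inhibitor, a lower number a stronger inhibitor), the lowest of the two numbers shown. Compound 1 `O=C1O/C(=C\Cn2ncc(=O)[nH]c2=O)C(OCc2ccccc2)=C1OCc1ccccc1` gives 20400 nM, and the step of a 22-fold lower number from compound 1 to compound 2 (1.35 log units; beyond the scatter) shows how strongly a change of this ring alone can move the result. Compound 3 `NC1(CCn2ccc(=O)[nH]c2=O)OC(=O)C(OCc2ccccc2)=C1OCc1ccccc1` reports only a limit, > 100000 nM. Compound 4 `O=C1O/C(=C\Cn2c(=O)[nH]c(=O)[nH]c2=O)C(OCc2ccccc2)=C1OCc1ccccc1` differs from compound 2 by a group of 9 heavy atoms (3 carbon, 3 nitrogen, 3 oxygen; one six-membered aromatic ring with 3 hetero atoms) in place of a group of 8 heavy atoms (3 carbon, 4 nitrogen, 1 oxygen; one six-membered aromatic ring with 3 hetero atoms), on a saturated chain carbon bound to a double-bonded chain carbon. Because a 22-fold lower number from compound 1 to compound 2 (1.35 log units; beyond the scatter) was large, a large shift is expected here too, most likely toward a weaker inhibitor. Compound 4 is therefore expected to give 10000 nM, within 2500 nM to 50000 nM. That expectation amounts to a step of an 11-fold higher number from compound 2 to compound 4 (1.04 log units; beyond the scatter).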

Compound 4, half-maximal inhibitory concentration: 37900 nM
For compound 4 the middle estimate is 3.8-fold (0.58 log units) below the measured one; the range from low to high includes it.
By their numbers in this assay, from the lowest: compound 2; then compounds 1 and 4 (each within the scatter of the next). At a limit, above all of these: compound 3.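

In this assay, putting the ring of compound 4 in place of the ring of compound 2 brings a 41-fold higher number from compound 2 to compound 4 (1.61 log units; beyond the scatter), a second large step at this place. By contrast, the other swap brings a 1.9-fold higher number from compound 1 to compound 4 (0.27 log units; within the scatter), so these two rings cannot be told apart, and only the ring of compound 2 stands out among these three. Nothing shown here explains this difference. From the compounds shown here alone, it remains open whether the amine on the ring of compound 2 accounts for its lower number, and how a ring carrying a carboxylic acid would read at this place.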